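Swapping the aryl group on the hydrazone of compound 3

A few compounds are considered here, and "the series" means these few. Any claim that something is new, unique, unknown or untested is made for them only; others in the source may bear on it.

Measured compounds:
compound 1 `Fc1ccccc1CSc1nnc(-c2ccncc2)n1-c1ccccc1` — > 50000 nM
compound 2 `Clc1ccc(CSc2nnc(-c3ccncc3)n2-c2ccccc2)cc1` — 16900 nM
compound 3 `COc1ccc(/C=N/NC(=O)CSc2nnc(-c3ccncc3)n2-c2ccccc2)cc1` — 27100 nM

In a functional assay on HepG2 cells (Homo sapiens) for inhibition, read by MTT assay, with a stated time of 48 h (on this read-out lower numbers stand for stronger inhibition and higher numbers for weaker inhibition), compound 1 gives only a limit of the assay, > 50000 nM. Compound 2 gives 16900 nM and compound 3 gives 27100 nM, so compound 3 holds the highest of the two actual numbers, though its gap to compound 2 lies within the scatter.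

Compound 4 `O=C(CSc1nnc(-c2ccncc2)n1-c1ccccc1)N/N=C/c1ccccc1F` differs from compound 3 by 2-fluorophenyl in place of 4-methoxyphenyl on a carbon with a double bond to nitrogen. Among the measured compounds shown here, the only measured step, an at least 2.9-fold lower number from compound 1 to compound 2 (0.47 log units; beyond the scatter), sits at a different place and runs the other way, toward a halogenated ring, so it gives no direct guide. For compound 4 a number near that of compound 3 or somewhat higher is therefore expected, a 1.3-fold higher number from compound 3 to compound 4 (0.11 log units; within the scatter). The estimate for compound 4 is 35000 nM, between 12000 nM and 100000 nM.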

Compound 4, half-maximal inhibitory concentration: 15200 nM
For compound 4 the middle estimate is 2.3-fold (0.36 log units) above the measured one; the measured number falls inside the stated range.
By their numbers in this assay, from the lowest: compounds 4, 2 and 3 (each within the scatter of the next). At a limit, above all of these: compound 1.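

On the carbon with a double bond to nitrogen, 2-fluorophenyl can replace 4-methoxyphenyl with no change that stands out from the scatter in this assay, with a 1.8-fold lower number from compound 3 to compound 4 (0.25 log units; within the scatter). This position therefore accepts either aryl group, and the hydrazone series keeps a real number here. Compound 1 alone gives a limit, and compound 4 does not: the limit of > 50000 nM in this assay, at which 1 of the 4 values shown sits.

Still open, on these data alone, is how an amine or a carboxylic acid on this aryl ring would read. So is whether a simple alkyl chain could replace the ring altogether.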